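A few compounds are considered here, and "the series" means these few. Any claim that something is new, unique, unknown or untested is made for them only; others in the source may bear on it.

In a physicochemical assay for solubility, with a stated time of 3 days, at pH 2 (on this read-out lower numbers stand for lower solubility and higher numbers for higher solubility), the record for this series is thin. Compound 1 `NC(=O)c1ccc2[nH]c(-c3ccc(OC4CCNCC4)cc3)nc2c1` carries the entry "not determined" (no result reported) in that read-out, and compound 2 `NC(=O)c1ccc2[nH]c(-c3ccc(OCC4CCCNC4)cc3)nc2c1` carries the entry "not determined" (no result reported) there too. Compound 3 `Cc1ccc(CN2CCCCC2CCOc2ccc(-c3nc4cc(C(N)=O)ccc4[nH]3)cc2)cc1` is recorded at > 400000 nM and this is a limit of the assay, not a number. Within the data shown here, the evidence in hand is thus the limit of > 400000 nM in this assay, at which 1 of the 3 values shown sits, and no pair of measured compounds offers a step for comparison.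

Compound 4 `NC(=O)c1ccc2[nH]c(-c3ccc(OCCC4CCCCN4C(=O)c4ccccc4)cc3)nc2c1` keeps the shared core and differs from compound 3 in one place, with benzoyl in place of 4-methylbenzyl on an amine nitrogen in a ring, next to the ring atom that bears a large group. The counted change is benzoyl in place of 4-methylbenzyl on an amine nitrogen in a ring and nothing else in the structure moves.

For this assay a step downward is expected, possibly beyond the usual scatter, although a second limit reading remains possible. The limit of compound 3 at > 400000 nM leaves a number room on the lower side only. The estimated step is an at least 2.6-fold lower number from compound 3 to compound 4 (0.42 log units; beyond the scatter) and it remains only an expectation. Compound 4 is expected at 150000 nM with an estimated range from 40000 nM to 400000 nM until a reading is available.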

Compound 4, solubility: 28000 nM
Compound 4: the middle estimate sits 5.4-fold (0.73 log units) above what was measured, outside the stated range (below it).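

In this assay, the exchange of 4-methylbenzyl for benzoyl on an amine nitrogen in a ring gives the series its first step, an at least 14-fold lower number from compound 3 to compound 4 (1.15 log units; beyond the scatter), which shows that the group at this place, next to the ring atom that bears a large group, can move the read-out well beyond the usual scatter. Among these compounds, the two groups have the same number of heavy atoms and the same aromatic ring of carbon only, and they differ by count in the carbonyl, which brings the hydrogen-bond acceptor, and in one carbon, while compound 4 gives the first actual number, 28000 nM. For compound 3 the entry > 400000 nM is a limit of the assay and not a number, and the size of the step rests on that entry: the limit of > 400000 nM in this assay, at which 1 of the 4 values shown sits.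

From the compounds shown here alone, what stays open is whether the carbonyl alone accounts for the step or whether the loss of the methyl on the aromatic ring also contributes. A plain benzyl or an acetyl on the same nitrogen would separate these parts, and the compounds shown offer no such comparison.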